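Inverting one stereocentre in compound 1: solubility at low pH

A few compounds are considered here, and "the series" means these few. Any claim that something is new, unique, unknown or untested is made for them only; others in the source may bear on it.

Measured so far:
compound 1, `CC(C)[C@@H](C[C@H]1SC(=O)NC1=O)c1ccc(-c2ccc3cccc(F)c3c2)[nH]c1=O`: 12200 nM
compound 2, `O=C1NC(=O)/C(=C/C(Cc2ccccc2)c2ccc(-c3ccc4cccc(F)c4c3)[nH]c2=O)O1`: 900 nM
compound 3, `CC(C)C(CC1NC(=O)NC1=O)c1ccc(-c2ccc3cccc(F)c3c2)[nH]c1=O`: 13000 nM

In a physicochemical assay for solubility, measured as kinetic solubility, at pH 2 (a lower number here means a less soluble compound, a higher number a more soluble compound), compound 1 gives 12200 nM. Compound 3 gives a number that lies within the scatter of that of compound 1, so nothing separates the two. Compound 2 gives a clearly lower number, beyond the scatter, so compound 2 is the least soluble of the three in this assay.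

Compound 4, `CC(C)[C@H](C[C@H]1SC(=O)NC1=O)c1ccc(-c2ccc3cccc(F)c3c2)[nH]c1=O`, differs from compound 1 as follows: the two compounds have the same atoms and bonds and differ only in configuration as drawn: 1 of 2 stereo elements differ; a stereocentre at a saturated chain carbon is drawn R in compound 1 and S in compound 4. Among the measured compounds shown here, no measured pair shows such a stereochemical inversion alone, so no measured step guides the expectation. Compound 4 is expected to keep a solubility close to that of compound 1, with a step of a 1.0-fold lower number from compound 1 to compound 4 (0.01 log units; within the scatter) that is not expected to exceed the scatter. Compound 4 is thus estimated at 12000 nM, in a range of 6000 nM to 25000 nM.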

Compound 4, solubility: 4900 nM
Beside the measured number, compound 4's estimate is 2.4-fold (0.39 log units) above it, outside the stated range (below it).
By their numbers in this assay, from the lowest: compound 2; then compound 4; then compounds 1 and 3 (each within the scatter of the next).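

In this assay, inverting the stereocentre at the saturated chain carbon gives a 2.5-fold lower number from compound 1 to compound 4 (0.40 log units; beyond the scatter). Configuration at this position alone therefore moves the read-out beyond the scatter, which the earlier compounds could not show, as no two of them differed in one place. The step can be assigned to this single centre because of the following: the fact that compounds 1 and 4 differ only in the configuration as drawn

The compounds shown leave open whether inverting the second stereocentre would have a comparable effect. They also leave open whether this step would persist in a compound carrying an amine or a carboxylic acid.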